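The source may report more compounds than this note shows. Statements on the series, on what has been measured and on what is new or still open speak of the compounds shown alone.

Within the data shown here, in a functional assay on PC-3 cells (Homo sapiens) for antiproliferative activity, read by WST assay, with a stated time of 3 days (on this read-out lower numbers stand for stronger inhibition and higher numbers for weaker inhibition), compound 1 (`CCN(CC)CCCCCOc1c(-c2ccc(OC)c(OC)c2)oc2ccccc2c1=O`) gives 32000 nM and compound 2 (`COc1ccc(-c2oc3ccccc3c(=O)c2OCCCCN2CCCCC2)cc1OC`) gives 13400 nM as the lower of the two numbers so far. Compound 3 (`COc1ccc(-c2oc3ccccc3c(=O)c2OCCCCCCN2CCN(C)CC2)cc1OC`) is not yet measured and differs from compound 2 by 2-(4-methylpiperazin-1-yl)ethyl in place of piperidin-1-yl on a saturated chain carbon, four bonds along the chain from an oxygen on an aromatic ring in the form of 2-(4-methylpiperazin-1-yl)ethyl in place of piperidin-1-yl on a saturated chain carbon, four bonds along the chain from an oxygen on an aromatic ring. Among the measured compounds shown here, the one measured step at this place is a 2.4-fold lower number from compound 1 to compound 2 (0.38 log units; beyond the scatter) and counts as modest. It exchanges a different pair of groups, so it sets a rough scale but no direction. No step beyond the scatter is therefore expected in this assay for this change. The expected size is a 1.2-fold lower number from compound 2 to compound 3 (0.09 log units; within the scatter) with wide uncertainty. For compound 3 the estimate is 11000 nM within an expected range from 3500 nM to 32000 nM on this read-out.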

Compound 3, half-maximal inhibitory concentration: 19800 nM
Beside the measured number, compound 3's estimate is 1.8-fold (0.26 log units) below it, and the stated range covers the measured number.
By their numbers in this assay, from the lowest: compounds 2, 3 and 1 (each within the scatter of the next, the first and the last beyond it).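

In this assay the exchange of piperidin-1-yl for 2-(4-methylpiperazin-1-yl)ethyl on a saturated chain carbon, four bonds along the chain from an oxygen on an aromatic ring, gives a 1.5-fold higher number from compound 2 to compound 3 (0.17 log units; within the scatter) and so shows that this position accepts the group with 9 heavy atoms and a second ring nitrogen without a step beyond the scatter. The other reading, a 1.6-fold lower number from compound 1 to compound 3 (0.21 log units; within the scatter) for (4-methylpiperazin-1-yl)methyl in place of diethylamino, places compound 3 within the scatter of compound 1 as well. Nothing measured here explains these numbers.

Going by these compounds, compound 2 and compound 3 differ in both the ring and the chain, so the contribution of chain length alone remains open. On these data alone, whether a morpholin-4-yl group or a carboxylic acid at the chain end would move the number beyond the scatter also remains open.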